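Carbamate to urea on the shared core: permeability outlook

The source may report more compounds than this note shows. Statements on the series, on what has been measured and on what is new or still open speak of the compounds shown alone.

Measured in an ADME assay for permeability, using PAMPA, at pH 7.4 (a higher number here means that the compound crosses the layer faster, a lower number that the compound crosses the layer more slowly), so far:
compound 1, `CCN(c1cc2oc(-c3ccc(F)cc3)c(C(=O)NC)c2cc1-c1cc(F)c(OC)c(C(=O)NC2(c3ncccn3)CC2)c1)S(C)(=O)=O` — compound 1 gives 659 nm/s
compound 2, `CCN(c1cc2oc(-c3ccc(F)cc3)c(C(=O)NC)c2cc1-c1cc(C)c(OC)c(C(=O)NC2(c3ncccn3)CC2)c1)S(C)(=O)=O` — compound 2 gives 409 nm/s
compound 3, `CCN(C(=O)OC)c1cc2oc(-c3ccc(F)cc3)c(C(=O)NC)c2cc1-c1ccc(OC)c(C(=O)NC2(c3ncccn3)CC2)c1` — compound 3 gives 660 nm/s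

Compound 3 stands at the top of these three numbers, but only nominally: its number matches that of compound 1 and sits within the scatter of compound 2 as well, so the three compounds are not separated in this assay. Within the data shown here, the one single-point step available, a 1.6-fold lower number from compound 1 to compound 2 (0.21 log units; within the scatter), concerns a methyl in place of fluoro on an aromatic carbon and stays within the scatter; it does not touch the part of the molecule changed here.

Compound 4, `CCN(C(=O)N(C)C)c1cc2oc(-c3ccc(F)cc3)c(C(=O)NC)c2cc1-c1ccc(OC)c(C(=O)NC2(c3ncccn3)CC2)c1`, differs from compound 3 in one place: dimethylamino in place of methoxy on a carbonyl carbon. Among the measured compounds shown here, no measured pair shows this change, so the expectation rests on the flat picture of compounds 1 to 3 alone. Compound 4 is therefore expected to stay close to compound 3 in this assay, with a step of a 1.3-fold lower number from compound 3 to compound 4 (0.10 log units; within the scatter) that should fall within the scatter. The estimate for compound 4 is 520 nm/s, with a range from 300 nm/s to 850 nm/s.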

Compound 4, apparent permeability: 575 nm/s
For compound 4 the middle estimate is 1.1-fold (0.04 log units) below the measured one, within the range that was stated.
By their numbers in this assay, from the lowest: compounds 2, 4, 1 and 3 (each within the scatter of the next).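

Working notes on the carbonyl position: dimethylamino in place of methoxy on a carbonyl carbon whose other neighbour is an amide-type nitrogen gives, in this assay, a 1.1-fold lower number from compound 3 to compound 4 (0.06 log units; within the scatter). Among these compounds, this is the first direct reading of methoxycarbonyl to dimethylcarbamoyl, and it shows that compound 3 and compound 4 are not separated at this position, so the urea can stand in for the carbamate here without a step beyond the scatter. No supporting data bear on what lies behind this result.

Open, going by these compounds, is how the same carbonyl carbon behaves with other groups on it, such as methylamino, a morpholine ring or a longer alkoxy chain like isopropoxy. Also open, on these data alone, is whether a propyl chain in place of the ethyl on the same nitrogen stays equally flat in this assay.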